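Lengthening a methoxy to ethoxy in a cytotoxicity series

The compounds below may be only part of what the source reports. "The series", "measured", "known", "first", "only" and "open" are said of these compounds alone.

Of the compounds shown here, three have been measured in a toxicity assay on Huh-7.5 cells (Homo sapiens) for inhibition, read by MTT assay, with a stated time of 96 h (on this read-out lower numbers stand for higher toxicity in this test and higher numbers for lower toxicity in this test), so far.

Compound 1 `CCC(=O)Nc1cc(C(=O)Nc2ccc(OC)cc2)ccc1OC(C)C` gives 113000 nM
Compound 2 `CCC(=O)Nc1cc(C(=O)Nc2ccc(OC)cc2)ccc1OCCCCl` gives 158000 nM
Compound 3 `CCC(=O)Nc1cc(C(=O)Nc2ccc(OC)cc2)ccc1OC` gives 109000 nM

Compound 3 has the lowest number of the three, yet it cannot be separated from the other two. Its nearest neighbour is compound 1 and its furthest is compound 2, and both gaps lie within the scatter. The next compound, compound 4 `CCOc1ccc(C(=O)Nc2ccc(OC)cc2)cc1NC(=O)CC`, is still unmeasured in this assay and differs from compound 3 by one small change (methyl in place of hydrogen on a saturated chain carbon bound to an oxygen on an aromatic ring). This places methyl in place of hydrogen on a saturated chain carbon bound to an oxygen on an aromatic ring, so methoxy becomes ethoxy.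

The measured steps that bear on this change all alter the group on that same oxygen. Methyl in place of isopropyl gives a 1.0-fold lower number from compound 1 to compound 3 (0.02 log units; within the scatter) and the change from 3-chloropropyl to methyl gives a 1.4-fold lower number from compound 2 to compound 3 (0.16 log units; within the scatter) while 3-chloropropyl in place of isopropyl gives a 1.4-fold higher number from compound 1 to compound 2 (0.15 log units; within the scatter) and so none of the three leaves the scatter. No step beyond the scatter is therefore expected, in either direction. The expected step is a 1.1-fold higher number from compound 3 to compound 4 (0.04 log units; within the scatter) and it stays small. For compound 4 the estimated value is 120000 nM (expected range 75000 nM to 190000 nM).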

Compound 4, half-maximal cytotoxic concentration: 73200 nM
For compound 4 the middle estimate is 1.6-fold (0.21 log units) above the measured one; measured number below the stated range.
By their numbers in this assay, from the lowest: compounds 4, 3, 1 and 2 (each within the scatter of the next, the first and the last beyond it).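

In this assay, going from methoxy to ethoxy gives a 1.5-fold lower number from compound 3 to compound 4 (0.17 log units; within the scatter) and going from isopropyl to ethyl on the same oxygen gives a 1.5-fold lower number from compound 1 to compound 4 (0.19 log units; within the scatter) so ethoxy cannot be told apart from either of these groups. Within the data shown here, what the earlier compounds did not show is a step on this oxygen that leaves the scatter: going from 3-chloropropyl to ethyl gives a 2.2-fold lower number from compound 2 to compound 4 (0.33 log units; beyond the scatter) and so the group here can shift the number, if only modestly, with the ethoxy and 3-chloropropyl compounds as the two ends of the series. Nothing measured here bears on the reason for this gap.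

The compounds shown leave open whether a longer chain such as butyl, or a chain ending in an amine or a carboxylic acid, would carry the number further from that of compound 4 in either direction. They also leave open what a plain propyl group on this oxygen would give, a comparison that would separate the chlorine from the length of the chain.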